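The compounds below may be only part of what the source reports. "The series", "measured", "known", "first", "only" and "open" are said of these compounds alone.

Measured in a functional assay on Raji cells (Homo sapiens) for cytotoxicity, with a stated time of 72 h; on this read-out higher numbers stand for an effect only at larger amounts of compound and lower numbers for an effect already at smaller amounts:

- Compound 1 `C=C[C@@](C)(/C=C/c1ccc(OCc2ccccc2)cc1)CCC=C(C)C` gives > 26000 nM, a limit.
- Compound 2 `C=C[C@@](C)(/C=C/c1ccc(OS(=O)(=O)C(F)(F)F)cc1)CCC=C(C)C` gives > 26000 nM, a limit.
- Compound 3 `C=C[C@@](C)(/C=C/c1ccc(O)cc1)CCC=O` gives > 26000 nM, a limit.

No number has been obtained so far in this series, and the shared position is the limit of > 26000 nM in this assay, at which 3 of the 3 values shown sit. Compound 3 therefore stands only at > 26000 nM, which is a limit and not a number. Its place relative to compound 1 and compound 2 cannot be ranked.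

The next compound is compound 4 `C=C[C@@](C)(/C=C/c1ccc(O)cc1)CCCO`. The change is hydroxymethyl in place of formyl on a saturated chain carbon, three bonds along the chain from two double-bonded chain carbons.

Among the measured compounds shown here, only one measured step is available, a step that the two limits leave unreadable from compound 1 to compound 2. It lies at a different place, on an oxygen on an aromatic ring, and gives no size to carry over. For the measured compounds named here, no measured step covers the formyl to hydroxymethyl change. Going by the values given here, the only anchor is compound 3 at > 26000 nM, again a limit.

On that basis, no step beyond the scatter is expected in this assay, in either direction. The estimated change is a number no higher from compound 3 to compound 4 (the limit leaves the size open). For compound 4 the estimated value is 26000 nM, with an expected range of 10000 nM to 50000 nM, and a report as a limit alone is the likeliest outcome.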

Compound 4, half-maximal effective concentration: > 26000 nM
Compound 4 was reported as a limit (the forecaster's own chance of this, stated with the estimate: 85%); the middle value sits exactly at the limit.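

The step from compound 3 to compound 4 in this assay, hydroxymethyl in place of formyl, cannot be read, as both values are limits and not numbers. The series stays at one shared position: the limit of > 26000 nM in this assay, at which 4 of the 4 values shown sit.

The compounds shown leave open what size this change, or any other change on the shared core, would have on a numeric value.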